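The source may hold more compounds than are shown below. What is called first, only, known or untested is meant among the compounds shown, and "the series" means these compounds.

Measured so far:
Compound 1 `FC(F)(F)c1cc(COC[C@@H](NCc2nc[nH]n2)c2ccccc2)cc(C(F)(F)F)c1`: in an assay on CHO cells for displacement of a labelled ligand from Substance-P receptor (Homo sapiens) (on this read-out lower numbers stand for stronger inhibition and higher numbers for weaker inhibition), compound 1 gives 5 nM
Compound 2 `CN(Cc1nnn(C)n1)[C@H](COCc1cc(C(F)(F)F)cc(C(F)(F)F)c1)c1ccccc1`: in this assay compound 2 gives 16 nM
Compound 3 `Cn1nnnc1CN[C@H](COCc1cc(C(F)(F)F)cc(C(F)(F)F)c1)c1ccccc1`: in this assay compound 3 gives 10 nM

Compound 3 sits second highest of the three numbers; its neighbours lie within the scatter on both sides, a 1.6-fold lower number from compound 2 to compound 3 (0.20 log units; within the scatter) and a 2.0-fold higher number from compound 1 to compound 3 (0.30 log units; within the scatter). Compound 4 `CCN(Cc1n[nH]c(O)n1)[C@H](COCc1cc(C(F)(F)F)cc(C(F)(F)F)c1)c1ccccc1` is not yet measured. The change is ethyl((5-hydroxy-1H-1,2,4-triazol-3-yl)methyl)amino in place of ((1-methyl-1H-tetrazol-5-yl)methyl)amino on a saturated chain carbon bound to an aromatic carbon and a saturated chain carbon. Among the compounds with values here, two measured steps bear on it: a substituent on the amine nitrogen together with a ring swap gave a 3.2-fold higher number from compound 1 to compound 2 (0.51 log units; beyond the scatter), while the ring swap alone gave a 2.0-fold higher number from compound 1 to compound 3 (0.30 log units; within the scatter). A similar small to modest rise in this assay is therefore expected for compound 4, roughly a 2.2-fold higher number from compound 3 to compound 4 (0.34 log units; beyond the scatter). For compound 4 the estimate in this assay is 22 nM, with a range from 8 nM to 60 nM.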

Compound 4, half-maximal inhibitory concentration: 0.8 nM
The estimate for compound 4 lay 28-fold (1.44 log units) above the measured number; the measured number lies below the stated range.
By their numbers in this assay, from the lowest: compound 4; then compounds 1, 3 and 2 (each within the scatter of the next, the first and the last beyond it).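

In this assay ethyl((5-hydroxy-1H-1,2,4-triazol-3-yl)methyl)amino on this saturated chain carbon gives the lowest number of the series, beyond the scatter against each other compound (a 13-fold lower number from compound 3 to compound 4 (1.10 log units; beyond the scatter)), (a 20-fold lower number from compound 2 to compound 4 (1.30 log units; beyond the scatter)) and (a 6.3-fold lower number from compound 1 to compound 4 (0.80 log units; beyond the scatter)). A substituted amine nitrogen is therefore compatible with a lower number than that of the unsubstituted compound 1, a result compound 2 did not show. No available evidence accounts for this gain.

The ethyl and the hydroxy group differ together, so their separate contributions remain unresolved. Also open, on these data alone, is how a longer chain on the nitrogen, or an amine or carboxylic acid in place of the hydroxy group, would read.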